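The compounds below may be only part of what the source reports. "The series", "measured", "known", "first", "only" and "open" are said of these compounds alone.

Compound 1, `O=Cc1c(O)ccc2oc(-c3ccco3)nc12`, in a functional assay on A549 cells (Homo sapiens) for cytotoxicity, read by MTT assay, with a stated time of 48 h (a lower number here means a stronger inhibitor, a higher number a weaker inhibitor), gives > 30000 nM, a limit of the assay rather than a number. Compound 2, `CC(=O)c1c(O)ccc2oc(-c3ccccc3C)nc12`, in this assay gives 20100 nM.

Among the compounds with values here, compound 2 thus holds the only real number measured so far. Compound 1 sits at the limit of > 30000 nM in this assay, at which 1 of the 2 values shown sits.

Compound 3, `CC(=O)c1c(O)ccc2oc(-c3ccccc3)nc12`, is not yet measured. It differs from compound 2 in one place: hydrogen in place of methyl on an aromatic carbon. Within the data shown here, no measured pair shows how this change plays out, so the step is expected to stay within the usual scatter, with the estimated move a 1.1-fold higher number from compound 2 to compound 3 (0.04 log units; within the scatter) small in either direction. For compound 3 the estimate is 22000 nM, between 8000 nM and 60000 nM.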

Compound 3, half-maximal inhibitory concentration: > 30000 nM
Compound 3 ended at the assay's limit (the forecaster's own chance of this, stated with the estimate: 30%); middle value at least 1.3-fold (0.13 log units) away from the limit.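

Hydrogen in place of methyl on this aromatic carbon, ortho to a large group, gives the first step that can be read in this series: an at least 1.4-fold higher number from compound 2 to compound 3 (0.17 log units; that floor lies within the scatter). In this assay compound 3 gives > 30000 nM, a limit of the assay. The step is therefore only a floor: the methyl may matter a good deal or hardly at all, since the true gap could be much larger or could stay within the scatter.

From the compounds shown here alone, how far compound 3 truly lies from compound 2 remains open. So does whether another group on this carbon, such as a methoxy group, a chlorine atom or an amine, would give a lower number.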